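A few compounds are considered here, and "the series" means these few. Any claim that something is new, unique, unknown or untested is made for them only; others in the source may bear on it.

Working notes on the series. Compound 1 `O=C(NCCCCn1cccn1)c1cccc(C2SCC(=O)N2c2cccnc2)c1` is the reference point. In a functional assay on HOS-TE85 cells (Homo sapiens) for inhibition, read by CCK-8 assay, with a stated time of 72 h (on this read-out lower numbers stand for stronger inhibition and higher numbers for weaker inhibition), compound 1 gives > 1000 nM, which is a limit of the assay rather than a number. Compound 2 `O=C(NCCCCc1ccccc1)c1cccc(C2SCC(=O)N2c2ccc(-c3ccccc3)cc2)c1` also sits at a limit in this assay, > 1000 nM. Compound 3 `COc1ccc(OC)c(N2C(=O)CSC2c2cccc(C(=O)NCCCCc3ccccc3)c2)c1` likewise returns a limit in this assay, > 1000 nM. For the measured compounds named here, the single measured step, a step that the two limits leave unreadable from compound 2 to compound 3, cannot be read in size or direction because of the limit of > 1000 nM in this assay, at which 3 of the 3 values shown sit. Going by the values given here, compound 1 therefore stands where every value so far stands, at the limit, and no ordering among the three can be drawn.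

Compound 4 `O=C(NCCCCn1cccn1)c1cccc(C2SCC(=O)N2c2ccncc2)c1` differs from compound 1 by pyridin-4-yl in place of pyridin-3-yl on an amide-type nitrogen in a ring. Among the compounds with values here, no measured step bears on a change of this kind; the only step available runs between two limits and gives no size. No step beyond the scatter is expected in this assay from this change. Compound 4 is estimated at 3000 nM, with a range from 800 nM to 20000 nM. This amounts to an expected step that the limit leaves unreadable from compound 1 to compound 4, most likely again reported only as a limit.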

Compound 4, half-maximal inhibitory concentration: > 1000 nM
Compound 4: a limit, no number; the forecaster's own chance of this, stated with the estimate: 80%; the middle value is on the limit's open side.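

No step can be read between compound 1 and compound 4 in this assay, because both values are limits: the limit of > 1000 nM in this assay, at which 4 of the 4 values shown sit.

The compounds shown leave open which structural change, if any, would give a number rather than a limit, and how the compounds would then rank.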